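From Butylamino to Piperidin-1-yl on a Thiocarbonyl Carbon

This account rests on a few compounds, and the source may have more. Where it says the series, first, only, none or still open, it means among the compounds named here.

- Compound 1 `CC(C)NC(=S)N/N=C1\CC(c2ccc(O)cc2)Oc2cc(O)ccc21`: 68100 nM
- Compound 2 `CC(C)(C)NC(=S)N/N=C1\CC(c2ccc(O)cc2)Oc2cc(O)ccc21`: 50000 nM
- Compound 3 `CCCCNC(=S)N/N=C1\CC(c2ccc(O)cc2)Oc2cc(O)ccc21`: > 100000 nM

In a functional assay on HeLa cells (Homo sapiens) for cytotoxicity, read by MTT assay, with a stated time of 72 h (on this read-out higher numbers stand for weaker inhibition and lower numbers for stronger inhibition), compound 3 gives > 100000 nM, which is a limit of the assay and not a number. Going by the values given here, it is the one compound at that limit: the limit of > 100000 nM in this assay, at which 1 of the 3 values shown sits.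

Compound 4 `Oc1ccc(C2C/C(=N\NC(=S)N3CCCCC3)c3ccc(O)cc3O2)cc1`, not yet measured, carries piperidin-1-yl in place of butylamino on a thiocarbonyl carbon.

Two measured steps change the group at this end of the molecule: an at least 1.4-fold higher number from compound 1 to compound 3 (0.16 log units; that floor lies within the scatter) and an at least 2.0-fold higher number from compound 2 to compound 3 (0.30 log units; that floor lies within the scatter). Both are floors within the scatter, as is a 1.4-fold lower number from compound 1 to compound 2 (0.13 log units; within the scatter). Among the compounds with values here, none of the measured compounds has a ring in this place, so the guide is loose. The expectation rests on compound 1 at 68100 nM and compound 2 at 50000 nM. Compound 4 may also reach the limit. An estimated step of an at least 1.4-fold lower number from compound 3 to compound 4 (0.15 log units; that floor lies within the scatter) is expected, with no firm change beyond the scatter in this assay. The expected value for compound 4 is 70000 nM, with an estimated range of 30000 nM to 100000 nM.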

Compound 4, half-maximal inhibitory concentration: 74400 nM
Compound 4: the middle estimate sits 1.1-fold (0.03 log units) below what was measured; low and high end bracket the measured number.
By their numbers in this assay, from the lowest: compounds 2, 1 and 4 (each within the scatter of the next). At a limit, above all of these: compound 3.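

In this assay, piperidin-1-yl on a thiocarbonyl carbon brings the only ring among these groups and, unlike butylamino, no hydrogen-bond donor, yet neither difference separates compound 4 from the branched compounds: a 1.1-fold higher number from compound 1 to compound 4 (0.04 log units; within the scatter), and a 1.5-fold higher number from compound 2 to compound 4 (0.17 log units; within the scatter). Against the straight chain the step reads an at least 1.3-fold lower number from compound 3 to compound 4 (0.12 log units; that floor lies within the scatter), so this change also shows no firm gain over butylamino. Compound 3 remains a limit and not a number: the limit of > 100000 nM in this assay, at which 1 of the 4 values shown sits.

The compounds shown leave open whether any group at this place can move the number beyond the scatter of these values, since all of them attach through nitrogen and carry only saturated carbon. A pyrrolidin-1-yl or morpholin-4-yl ring, or a phenylamino group, would test whether the ring itself or the carbon groups on that nitrogen matter here.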